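From Compound 2 to Compound 3: A Phenyl Swap

The source may hold more compounds than are shown below. What is called first, only, known or untested is meant among the compounds shown, and "the series" means these compounds.

Values measured in a functional assay on SW480 cells (Homo sapiens) for antiproliferative activity, read by sulforhodamine B assay, with a stated time of 48 h (on this read-out higher numbers stand for weaker inhibition and lower numbers for stronger inhibition), so far

- Compound 1 `COc1ccc(OC)c(/C=C/C(=O)C(=Cc2ccc(OC)c(OC)c2)C(=O)/C=C/c2cc(OC)ccc2OC)c1` gives 560 nM
- Compound 2 `COc1ccc(OC)c(/C=C/C(=O)C(=Cc2cc(OC)c(O)c(OC)c2)C(=O)/C=C/c2cc(OC)ccc2OC)c1` gives 500 nM

Only these two values exist, and compound 2 stands level with compound 1, the gap lying within the scatter. Compound 3 `COc1ccc(OC)c(/C=C/C(=O)C(=Cc2ccc(OC)c(O)c2)C(=O)/C=C/c2cc(OC)ccc2OC)c1` carries 3-hydroxy-4-methoxyphenyl in place of 4-hydroxy-3,5-dimethoxyphenyl on a double-bonded chain carbon bound to a double-bonded chain carbon, and 3-hydroxy-4-methoxyphenyl in place of 4-hydroxy-3,5-dimethoxyphenyl on a double-bonded chain carbon bound to a double-bonded chain carbon is the counted difference. Among the measured compounds shown here, the one measured step bearing on this swap, made at the same place, is a 1.1-fold lower number from compound 1 to compound 2 (0.05 log units; within the scatter) in size. For the measured compounds named here, no measured compound carries the entering group, so no direction can be given, and no step beyond the scatter is expected in this assay here. The estimated change is a 1.0-fold lower number from compound 2 to compound 3 (0.02 log units; within the scatter) on this reasoning. For compound 3 the expected value is 480 nM as an estimate, within an expected range of 220 nM to 1050 nM overall.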

Compound 3, half-maximal inhibitory concentration: 1120 nM
Compound 3: middle estimate off by 2.3-fold (0.37 log units), on the low side, and the stated range ends below it.
By their numbers in this assay, from the lowest: compounds 2, 1 and 3 (each within the scatter of the next, the first and the last beyond it).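

In this assay, among the compounds shown here, the group on a double-bonded chain carbon bound to a double-bonded chain carbon proved able to shift the result: 3-hydroxy-4-methoxyphenyl in place of 4-hydroxy-3,5-dimethoxyphenyl gives a 2.2-fold higher number from compound 2 to compound 3 (0.35 log units; beyond the scatter), the first step in this set beyond the scatter. The smaller edit, hydrogen in place of methyl on an oxygen on an aromatic ring, gives a 2.0-fold higher number from compound 1 to compound 3 (0.30 log units; within the scatter), so that change alone cannot be read as a real loss. No measurement at hand accounts for the size of either step.

The compounds shown leave open which part of the difference between the two phenyl groups carries the step, as the hydroxy and methoxy pattern differs as a whole. They also leave open how an amino group or a fluorine in place of the hydroxy group would read.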